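Same Atoms, New Arrangement on a Sulfonamide

This account rests on a few compounds, and the source may have more. Where it says the series, first, only, none or still open, it means among the compounds named here.

Of the compounds shown here, three have been measured in a functional assay (Homo sapiens) for antiproliferative activity, read by sulforhodamine B assay, with a stated time of 48 h; on this read-out higher numbers stand for weaker inhibition and lower numbers for stronger inhibition. Compound 1 `O=C1NCCN1c1ccc(S(=O)(=O)Nc2ccc3[nH]ccc3c2)cc1` gives 770 nM, compound 2 `CCc1cccc(NS(=O)(=O)c2ccc(N3CCNC3=O)cc2)c1` gives 270 nM, and compound 3 `COc1cc(NS(=O)(=O)c2ccc(N3CCNC3=O)cc2)cc(OC)c1OC` gives 58 nM. Compound 2 therefore sits in the middle of the three, with clear gaps to both of the others. These three compounds differ only in the group on the sulfonamide nitrogen, and their values show that this group can matter.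

Compound 4 `Cc1ccc(C)c(NS(=O)(=O)c2ccc(N3CCNC3=O)cc2)c1` has not yet been measured. It differs from compound 2 in one place: 2,5-dimethylphenyl in place of 3-ethylphenyl on a sulfonamide nitrogen, with 2,5-dimethylphenyl in place of 3-ethylphenyl on a sulfonamide nitrogen. The two compounds have the same atoms, joined differently. Going by the values given here, no measured pair differs in just one place, and the data offer no direct guide to this change.

With no evidence for either direction, the expected change is none beyond the scatter, and the estimated step of a 1.1-fold higher number from compound 2 to compound 4 (0.05 log units; within the scatter) is small. For compound 4, the expected value is 300 nM, with an estimated range of 100 nM to 900 nM.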

Compound 4, half-maximal inhibitory concentration: 86 nM
Beside the measured number, compound 4's estimate is 3.5-fold (0.54 log units) above it; measured number below the stated range.
By their numbers in this assay, from the lowest: compounds 3 and 4 (each within the scatter of the next); then compound 2; then compound 1.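

In this assay, rearranging the group on the sulfonamide nitrogen gives a 3.1-fold lower number from compound 2 to compound 4 (0.50 log units; beyond the scatter) and this step lies beyond the scatter. The earlier compounds shown here carry different groups at this position, whereas 3-ethylphenyl and 2,5-dimethylphenyl have the same count of carbon atoms, the same kind of ring and no hydrogen-bond donors or acceptors, so the way these carbons are arranged is enough to shift the number, with nothing added or removed. No measurement here explains why this arrangement gives the lower number. On these data alone, it remains open which of the two methyl groups of 2,5-dimethylphenyl carries the step. As far as these compounds go, it is also open whether an amine, a carboxylic acid or a longer chain on this ring would give a similar number.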